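This account rests on a few compounds, and the source may have more. Where it says the series, first, only, none or still open, it means among the compounds named here.

Series notes. For the measured compounds named here, compound 1 `CCN1CCC(CC(=O)NC2(c3ccc(Cl)c(Cl)c3)C(=O)Nc3cc(Cl)cc(Cl)c32)CC1` is the reference point in an in vitro functional assay on CHO-CREluc cells for antagonist activity at growth hormone secretagogue receptor type 1 (Homo sapiens), read by a luciferase reporter, with a stated time of 4 h (on this read-out lower numbers stand for stronger inhibition and higher numbers for weaker inhibition), where compound 1 gives 1 nM, the lowest of the two numbers measured so far. The other measured compound, compound 2 `CN1CCN(CC(=O)NC2(c3ccc(C(C)(C)C)cc3)C(=O)Nc3cc(Cl)c(Cl)cc32)CC1`, differs from compound 1 in more than one place; in this assay compound 2 gives 1470 nM. Going by the values given here, the two values lie far apart, beyond the scatter, but no single-point step connects them, so nothing is read from that gap about any one change.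

Compound 3 `CCN1CCN(CC(=O)NC2(c3ccc(Cl)c(Cl)c3)C(=O)Nc3cc(Cl)cc(Cl)c32)CC1` is not yet measured. It differs from compound 1 in one place: 4-ethylpiperazin-1-yl in place of 1-ethylpiperidin-4-yl on a saturated chain carbon bound to a carbonyl carbon. The rest of the structure is kept. Among the compounds with values here, no measured pair shows the effect of this exchange, so the only anchor is compound 1 at 1 nM, which sits at a very low number; more room lies above it than below it. The step is estimated as a 3.0-fold higher number from compound 1 to compound 3 (0.48 log units; beyond the scatter), a small shift towards a higher number, close to the scatter. In this assay compound 3 is expected at 3 nM, with a range from 0.7 nM to 15 nM.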

Compound 3, half-maximal inhibitory concentration: 7 nM
Beside the measured number, compound 3's estimate is 2.3-fold (0.37 log units) below it; the measured number falls inside the stated range.
By their numbers in this assay, from the lowest: compound 1; then compound 3; then compound 2.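

Notes on the side chain. In this assay, for the compounds shown here, the exchange of 1-ethylpiperidin-4-yl for 4-ethylpiperazin-1-yl on a saturated chain carbon bound to a carbonyl carbon gives the first single-place step, a 7.0-fold higher number from compound 1 to compound 3 (0.85 log units; beyond the scatter), which is modest but beyond the scatter. This place therefore responds to a change from a six-membered non-aromatic ring with 1 hetero atom to one with 2 hetero atoms, even with the heavy-atom count of the group held at 8 and the rest of the structure kept, and compound 3 still gives a low number, 7 nM. Nothing measured here accounts for the size or direction of this step.

The compounds shown leave open how a morpholin-4-yl ring, or a propyl chain in place of the ethyl on the piperazine, would read at this place on the core of compound 1. Going by these compounds alone, they also leave open whether the same exchange gives a similar step on a core carrying other aryl and chloro substituents, since only one such pair is available.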